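Piperidin-1-yl for diethylamino at the chain end

A few compounds are considered here, and "the series" means these few. Any claim that something is new, unique, unknown or untested is made for them only; others in the source may bear on it.

Measured so far in an ADME assay (liver) for metabolic stability, with Liver microsome (Homo sapiens) as the target, read by LC-MS, using microsomes, tested at 1 uM; a higher number here means that the compound lasts longer, a lower number that the compound disappears faster:
compound 1 `CCN(CC)CCCCN/C(=N\c1ccnc2cc(Cl)ccc12)C(C)C` — 0.917 h
compound 2 `CCN(CC)CCCCN/C(C)=N\c1ccnc2cc(Cl)ccc12` — > 1 h, a limit of the assay and not a number
compound 3 `CCN(CC)CCCN/C(=N\c1ccnc2cc(Cl)ccc12)c1cccnc1` — 0.6 h

Compound 1 and compound 3 lie within the usual scatter of each other, so no order between the two can be read. Compound 2 sits at the limit of > 1 h in this assay, at which 1 of the 3 values shown sits, which gives no number. Going by the values given here, the one step that can be read, an at least 1.0-fold higher number from compound 1 to compound 2 (0.03 log units; that floor lies within the scatter), rests at the floor of what the data can show and concerns the carbon with a double bond to nitrogen, not the amine end of the chain.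

Compound 4 `CC(C)/C(=N/c1ccnc2cc(Cl)ccc12)NCCCCN1CCCCC1` differs from compound 1 by piperidin-1-yl in place of diethylamino on a saturated chain carbon, four bonds along the chain from an amine nitrogen. Among the compounds with values here, no measured pair changes this amine. The nearest comparison, compound 1 against compound 3, alters the chain and the group on the carbon with a double bond to nitrogen at once, so it says nothing clean about the amine alone. Within the data shown here, with no step bearing on the change, the expectation is no shift beyond the scatter. Compound 4 is therefore expected to give 0.9 h, with a range from 0.5 h to 1.6 h. As a step this estimate reads a 1.0-fold lower number from compound 1 to compound 4 (0.01 log units; within the scatter). The value of compound 1 is close enough to the assay limit that a limit-only reading for compound 4 remains a real possibility.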

Compound 4, half-life: 0.483 h
Compound 4: middle estimate off by 1.9-fold (0.27 log units), on the high side; the measured number lies below the stated range.
By their numbers in this assay, from the lowest: compounds 4, 3 and 1 (each within the scatter of the next). At a limit, above all of these: compound 2.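

Going by these compounds alone, the only measured pair that changes the amine at the chain end gives, in this assay, a 1.9-fold lower number from compound 1 to compound 4 (0.28 log units; within the scatter). Within the data shown here, this is the first direct reading for piperidin-1-yl in place of diethylamino on a saturated chain carbon, four bonds along the chain from an amine nitrogen: replacing the open diethylamino group with one six-membered non-aromatic ring gives a half-life that this read-out cannot separate from that of compound 1, and compound 4 gives a number, 0.483 h, not a limit. No measurement shown here accounts for the size of this step, and as a single pair within the scatter it sets no trend for the amine end of the chain.

On these data alone, it remains open whether morpholin-4-yl, pyrrolidin-1-yl or dimethylamino at the same place would also stay within the scatter of diethylamino, or would move the half-life beyond it. As far as these compounds go, it is also open whether piperidin-1-yl would read the same way on a 3-(piperidin-1-yl)propyl chain, or with methyl in place of isopropyl on the carbon with a double bond to nitrogen.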